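Fluoro to methoxy on a weakly active compound

The source may report more compounds than this note shows. Statements on the series, on what has been measured and on what is new or still open speak of the compounds shown alone.

Compound 1 `COc1cc(-c2nccn2C(C)C)cc(OC)c1OC`: > 100000 nM (a limit)
Compound 2 `COc1cc(-c2nccn2-c2ccc(F)cc2)cc(OC)c1OC`: 38400 nM

In a functional assay on MDA-MB-231 cells (Homo sapiens) for antiproliferative activity, read by MTT assay, with a stated time of 72 h (a lower number here means a stronger inhibitor, a higher number a weaker inhibitor), compound 1 gives > 100000 nM, which is a limit of the assay and not a number. Among the measured compounds shown here, compound 2, at 38400 nM, holds the only true number so far. For the measured compounds named here, the one measured step, an at least 2.6-fold lower number from compound 1 to compound 2 (0.41 log units; beyond the scatter), rests on that limit of > 100000 nM in this assay, at which 1 of the 2 values shown sits, and concerns another change, so it offers only weak guidance. Compound 3 `COc1ccc(-n2ccnc2-c2cc(OC)c(OC)c(OC)c2)cc1` carries methoxy in place of fluoro on an aromatic carbon, para to a large group (methoxy in place of fluoro on an aromatic carbon). Going by the values given here, no measured step covers this swap, so no shift beyond the scatter is expected in this assay. The expected change is a 1.3-fold lower number from compound 2 to compound 3 (0.11 log units; within the scatter). For compound 3 the estimate is 30000 nM, with an expected range of 10000 nM to 90000 nM.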

Compound 3, half-maximal inhibitory concentration: 2700 nM
Beside the measured number, compound 3's estimate is 11-fold (1.05 log units) above it; the whole stated range lies above it.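

Swapping 4-fluorophenyl for 4-methoxyphenyl matters far more than expected: in this assay it gives a 14-fold lower number from compound 2 to compound 3 (1.15 log units; beyond the scatter), so one small group at this position can move the number well beyond the scatter. Compared with the isopropyl group on the nitrogen, the 4-methoxyphenyl group gives an at least 37-fold lower number from compound 1 to compound 3 (1.56 log units; beyond the scatter). Compound 1 stands at a limit and not a number, so that step has no fixed size: the limit of > 100000 nM in this assay, at which 1 of the 3 values shown sits.

The compounds shown leave open whether a longer chain such as ethoxy, or an amine, at this same place would lower the number further. They also leave open whether methoxy would have a similar effect elsewhere on the ring.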